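Nitrogen-linked arylmethyl variation on the shared nucleoside core

This account rests on a few compounds, and the source may have more. Where it says the series, first, only, none or still open, it means among the compounds named here.

Measured compounds:
compound 1, `Nc1nc(O)c2c(n1)n(C1OC(CO)[C@@H](O)[C@H]1O)c(=O)n2Cc1ccc(Cl)cc1`, 14 uM
compound 2, `Nc1nc(O)c2c(n1)n(C1OC(CO)[C@@H](O)[C@H]1O)c(=O)n2Cc1ccc([N+](=O)[O-])cc1`, 40 uM
compound 3, `Nc1nc(O)c2c(n1)n(C1OC(CO)[C@@H](O)[C@H]1O)c(=O)n2C/C=C/c1ccccc1`, 103 uM

In a functional assay (B cells) with Mus musculus as the target (on this read-out higher numbers stand for an effect only at larger amounts of compound and lower numbers for an effect already at smaller amounts), compound 3 gives 103 uM, the highest of the three numbers; the nearest is compound 2 with 40 uM, and the furthest is compound 1 with 14 uM. Both steps onto compound 3 run the same way: a 7.4-fold higher number from compound 1 to compound 3 (0.87 log units; beyond the scatter) and a 2.6-fold higher number from compound 2 to compound 3 (0.41 log units; beyond the scatter), each beyond the scatter.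

Compound 4 is `N#Cc1ccc(Cn2c(=O)n(C3OC(CO)[C@@H](O)[C@H]3O)c3nc(N)nc(O)c32)cc1`, not yet measured. Its change from compound 3 is 4-cyanophenyl in place of 2-phenylethenyl on a saturated chain carbon bound to an aromatic nitrogen; cut one bond further out it reads 3-phenylprop-2-en-1-yl to 4-cyanobenzyl. This reverses the kind of change seen in the two steps onto compound 3, which both raised the number, so a lower number is expected for compound 4 in this assay, roughly back into the range of compounds 1 and 2. Between those two the step of a 2.9-fold higher number from compound 1 to compound 2 (0.46 log units; beyond the scatter) gives some sense of how much different groups on the benzyl ring can shift the number.

Compound 4 is therefore estimated at 25 uM in this assay, within 8 uM to 80 uM. This estimate corresponds to an expected step of a 4.1-fold lower number from compound 3 to compound 4 (0.61 log units; beyond the scatter).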

Compound 4, concentration for half-maximal effect: 15 uM
Compound 4: middle estimate off by 1.7-fold (0.22 log units), on the high side, within the range that was stated.
By their numbers in this assay, from the lowest: compounds 1 and 4 (each within the scatter of the next); then compound 2; then compound 3.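

In this assay, the 4-cyanobenzyl group restores a low number relative to the 3-phenylprop-2-en-1-yl group, with a 6.9-fold lower number from compound 3 to compound 4 (0.84 log units; beyond the scatter), so the high number of compound 3 is not shared by any of the three benzyl compounds shown. On the aromatic carbon, cyano in place of nitro gives a 2.7-fold lower number from compound 2 to compound 4 (0.43 log units; beyond the scatter), a step beyond the scatter, so this position does discriminate between these two groups. Cyano in place of chloro gives a 1.1-fold higher number from compound 1 to compound 4 (0.03 log units; within the scatter), so these two compounds cannot be told apart, and nitro is the only one of the three ring groups that stands apart.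

Nothing available explains why nitro separates from chloro and cyano. Open, on these data alone, is how an amine or a carboxylic acid on that aromatic carbon would read, and whether a longer saturated chain to the ring would move the number.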